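Urea side chains in the U-87 MG series

The source may report more compounds than this note shows. Statements on the series, on what has been measured and on what is new or still open speak of the compounds shown alone.

Measured in a functional assay on U-87MG ATCC cells for cytotoxicity against U-87 MG (Homo sapiens), read by MTT assay, with a stated time of 72 h; a lower number here means a stronger inhibitor, a higher number a weaker inhibitor:
- compound 1 `COc1ncc(-c2ccc3nc(NC(=O)N4CCCC4)nn3c2)cc1NS(=O)(=O)c1ccc(F)cc1`: 1690 nM
- compound 2 `COc1ncc(-c2ccc3nc(NC(=O)N(C)C)nn3c2)cc1NS(=O)(=O)c1ccc(F)cc1`: 1780 nM
- compound 3 `COc1ncc(-c2ccc3nc(NC(=O)NCCN4CCCCC4)nn3c2)cc1NS(=O)(=O)c1ccc(F)cc1`: 1080 nM

Compound 3 gives the lowest of the three numbers, but it cannot be separated from the other two: the data show a 1.6-fold lower number from compound 1 to compound 3 (0.19 log units; within the scatter) and a 1.6-fold lower number from compound 2 to compound 3 (0.22 log units; within the scatter). The remaining pair shows a 1.1-fold higher number from compound 1 to compound 2 (0.02 log units; within the scatter). All three steps change the group on the same carbonyl carbon, so they are the closest evidence for the next step, and none exceeds the scatter.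

Compound 4 `COc1ncc(-c2ccc3nc(NC(=O)NCC(=O)N4CCOCC4)nn3c2)cc1NS(=O)(=O)c1ccc(F)cc1` differs from compound 3 in one place: (morpholin-4-yl)carbonyl in place of (piperidin-1-yl)methyl on a saturated chain carbon bound to an amide-type nitrogen. The change lies on a saturated chain carbon bound to an amide-type nitrogen. Within the data shown here, no measured compound carries (morpholin-4-yl)carbonyl, so the steps above bear on it only indirectly, and the range has to stay wide.

In this assay, the expected step is a 1.5-fold higher number from compound 3 to compound 4 (0.17 log units; within the scatter), and no change beyond the scatter is expected. The estimate for compound 4 is 1600 nM, with an expected range from 750 nM to 3500 nM.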

Compound 4, half-maximal inhibitory concentration: 3260 nM
Beside the measured number, compound 4's estimate is 2.0-fold (0.31 log units) below it; measured number inside the range.
By their numbers in this assay, from the lowest: compounds 3, 1, 2 and 4 (each within the scatter of the next, the first and the last beyond it).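

In this assay, among these compounds, this saturated chain carbon bound to an amide-type nitrogen gives the first change in the urea side chain that clears the scatter: with (morpholin-4-yl)carbonyl in place of (piperidin-1-yl)methyl, the data show a 3.0-fold higher number from compound 3 to compound 4 (0.48 log units; beyond the scatter). The separation holds only against the piperidine-bearing side chain, since the data also show a 1.8-fold higher number from compound 2 to compound 4 (0.26 log units; within the scatter) and a 1.9-fold higher number from compound 1 to compound 4 (0.29 log units; within the scatter), so the dimethylamino and pyrrolidin-1-yl ureas cannot be separated from either end of the series. No measurement in hand accounts for the step.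

The change swaps the ring and adds the carbonyl in a single step, so the compounds shown cannot assign the step to either part; a 2-(morpholin-4-yl)ethyl side chain and a ((piperidin-1-yl)carbonyl)methyl side chain on the same urea would separate the two. Also open, from the compounds shown here alone, is how far the side chain's end group matters at all, which a 2-(dimethylamino)ethyl side chain or a longer chain ending in piperidin-1-yl could test.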